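This account rests on a few compounds, and the source may have more. Where it says the series, first, only, none or still open, it means among the compounds named here.

Of the compounds shown here, two have so far been measured in an assay on HEK293 cells for agonist activity at P2X purinoceptor 4 (Homo sapiens), read by calcium flux, with stated times of 1 h and 30 min, in the presence of a further agent that is not named here; on this read-out lower numbers stand for stronger inhibition and higher numbers for weaker inhibition. Compound 1, with structure `COc1ccc(C(=O)O[C@@H]2[C@H](OC(=O)c3ccc(OC)cc3)[C@@H](COP(=O)(O)OP(=O)(O)OP(=O)(O)O)O[C@H]2n2cnc3c(N)ncnc32)cc1`, gives only a limit there: in this assay compound 1 reads > 100000 nM, the edge of what the test reports rather than a measured number. Going by the values given here, compound 2, with structure `O=P(O)(O)OP(=O)(O)OP(=O)(O)OC[C@H]1O[C@@H](n2cnc3c(Nc4ccccc4)ncnc32)[C@H](O)[C@@H]1O`, is the only compound with a genuine number: in this assay compound 2 gives 891 nM, so it stands as the sole reference point. Compound 3, with structure `O=P(O)(O)OP(=O)(O)OP(=O)(O)OC[C@H]1O[C@@H](n2cnc3c(NCc4ccccc4)ncnc32)[C@H](O)[C@@H]1O`, has not yet been measured. It differs from compound 2 in one place: benzyl in place of phenyl on a nitrogen on an aromatic ring. Among the compounds with values here, no measured pair in this set shows the effect of such a change, so the expectation rests on compound 2 alone. That change is expected to shift the value by a 1.7-fold higher number from compound 2 to compound 3 (0.23 log units; within the scatter), a modest step toward weaker inhibition at most, possibly no more than the scatter. Compound 3 is therefore estimated at about 1500 nM, within a range from 300 nM to 8000 nM.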

Compound 3, half-maximal inhibitory concentration: > 100000 nM
Compound 3: only a limit was reported; the forecaster's own chance of this, stated with the estimate: 10%; at least 66-fold (1.82 log units) between middle value and limit.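

On a nitrogen on an aromatic ring, the swap of phenyl for benzyl proves far from minor: in this assay it gives an at least 110-fold higher number from compound 2 to compound 3 (2.05 log units; beyond the scatter). Phenyl and benzyl both hold one six-membered aromatic ring of carbon only and neither brings hydrogen-bond donors or acceptors, yet the measurable inhibition seen with compound 2 does not survive this change. The step is a lower bound rather than a measured size, since compound 3 gives only a limit of the assay: the limit of > 100000 nM in this assay, at which 2 of the 3 values shown sit.

The compounds shown leave open whether other groups on this nitrogen, such as a methyl, a phenethyl with its longer chain, or a phenyl carrying a methoxy group or a carboxylic acid, keep any inhibition. Going by these compounds, what in the change from anilino to benzylamino produces the loss also remains unknown.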